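The source may report more compounds than this note shows. Statements on the series, on what has been measured and on what is new or still open speak of the compounds shown alone.

Values in a functional assay on SK-MEL-28 cells (Homo sapiens) for cytotoxicity; on this read-out higher numbers stand for weaker inhibition and lower numbers for stronger inhibition:
- compound 1 `CC(C)=CCCC1=CCC2=C(C1)C(=O)C(C)=CC2=O`: 9800 nM
- compound 2 `CC(=O)Oc1cc(C)c(OC(C)=O)c2cc(CCC=C(C)C)ccc12`: 3500 nM
- compound 3 `CC(C)=CCCc1ccc2c(c1)C(=O)C=CC2=O`: 400 nM

Compound 3 has the lowest number of the three, and its gaps to the other two lie beyond the scatter. Compound 2 is its nearest neighbour and compound 1 its furthest.

The next compound, compound 4 `CC(C)=CCCc1ccc2c(c1)C(=O)C(C)=CC2=O`, has methyl in place of hydrogen on a double-bonded ring carbon of compound 3: methyl in place of hydrogen on a double-bonded ring carbon. Among the measured compounds shown here, no measured pair isolates this change. Compound 2 at 3500 nM and compound 1 at 9800 nM both carry a methyl and both read higher than compound 3, but each also differs from it elsewhere, so they give only a weak hint of direction. A modest loss of inhibition is therefore expected, and a result within the scatter would not be surprising. The estimated change is a 2.0-fold higher number from compound 3 to compound 4 (0.30 log units; within the scatter), towards a higher number. For compound 4 the expected value is 800 nM, with an estimated range from 300 nM to 2500 nM.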

Compound 4, half-maximal inhibitory concentration: 9800 nM
Estimate against measurement, compound 4: 12-fold (1.09 log units) below; measured number above the stated range.
By their numbers in this assay, from the lowest: compound 3; then compound 2; then compounds 1 and 4 (each within the scatter of the next).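

Methyl in place of hydrogen on a double-bonded ring carbon gives a 25-fold higher number from compound 3 to compound 4 (1.39 log units; beyond the scatter) in this assay as the only change, the first reading of this position on its own. The added methyl, a single heavy atom, is enough for a step beyond the scatter, so in this series the read-out responds sharply to substitution at this ring carbon, and the low number belongs to the form with hydrogen there. No measurement on hand accounts for the size of this step.

From the compounds shown here alone, compounds 3 and 4 show only hydrogen and methyl on this carbon, so whether an ethyl, a methoxy or an amine there would read close to compound 3 or close to compound 4 stays open. Going by these compounds, whether the same step would appear on the core of compound 1 also stays open.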